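Dimethoxyquinazoline anilides: varying the benzamide ring

The source may report more compounds than this note shows. Statements on the series, on what has been measured and on what is new or still open speak of the compounds shown alone.

Measured compounds:
compound 1, `COc1cc2ncnc(Nc3ccc(NC(=O)c4ccc(C)cc4)cc3)c2cc1OC`, 25000 nM
compound 2, `COc1cc2ncnc(Nc3ccc(NC(=O)c4ccc(Cl)cc4)cc3)c2cc1OC`, 28000 nM
compound 3, `COc1cc2ncnc(Nc3ccc(NC(=O)c4ccc(C(F)(F)F)cc4)cc3)c2cc1OC`, > 100000 nM

In a functional assay on HepG2 cells (Homo sapiens) for inhibition, read by MTT assay (on this read-out lower numbers stand for stronger inhibition and higher numbers for weaker inhibition), compound 1 gives 25000 nM, the lower of the two numbers reported, with compound 2 nearest at 28000 nM; the step of a 1.1-fold higher number from compound 1 to compound 2 (0.05 log units; within the scatter) is within the scatter, so no order between the two can be claimed. For compound 3 the assay reports only a limit, > 100000 nM, and not a number. The steps of an at least 4.0-fold higher number from compound 1 to compound 3 (0.60 log units; beyond the scatter) and an at least 3.5-fold higher number from compound 2 to compound 3 (0.55 log units; beyond the scatter) both reach (the limit of > 100000 nM in this assay, at which 1 of the 3 values shown sits).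

Compound 4, `COc1cc2ncnc(Nc3ccc(NC(=O)c4c(F)cccc4F)cc3)c2cc1OC`, differs from compound 1 in one place: 2,6-difluorophenyl in place of 4-methylphenyl on a carbonyl carbon. Among the compounds with values here, none of the measured steps involves a 2,6-difluorophenyl group, so the measured steps bear on the change only loosely. Both measured replacements of methyl on the benzamide ring gave either an unchanged number or a weaker one, so the step is expected to be small to modest and, if anything, upward in this assay. Compound 4 is therefore estimated at 40000 nM, between 15000 nM and 110000 nM, a step of a 1.6-fold higher number from compound 1 to compound 4 (0.20 log units; within the scatter).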

Compound 4, half-maximal inhibitory concentration: 17000 nM
The estimate for compound 4 lay 2.4-fold (0.37 log units) above the measured number, and the stated range covers the measured number.
By their numbers in this assay, from the lowest: compounds 4, 1 and 2 (each within the scatter of the next). At a limit, above all of these: compound 3.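

In this assay, the 2,6-difluorophenyl group on this carbonyl carbon cannot be separated from the earlier rings carrying a single group, as neither a 1.5-fold lower number from compound 1 to compound 4 (0.17 log units; within the scatter) nor a 1.6-fold lower number from compound 2 to compound 4 (0.22 log units; within the scatter) exceeds the scatter. In contrast, an at least 5.8-fold lower number from compound 3 to compound 4 (0.76 log units; beyond the scatter) shows that the weak result for compound 3 does not extend to every fluorine-bearing ring at this place. The value of compound 3 remains a limit and not a number, so the true size of that step stays unknown: the limit of > 100000 nM in this assay, at which 1 of the 4 values shown sits.

The compounds shown leave open whether an amine, a carboxylic acid or a morpholine on the benzamide ring would move the number beyond the scatter of compound 1. They also leave open how much of the number of compound 4 depends on the fluorine atoms themselves and how much on where they sit.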